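Changing One Phenyl Group on a Shared Core

The source may hold more compounds than are shown below. What is called first, only, known or untested is meant among the compounds shown, and "the series" means these compounds.

Three compounds sharing one core have been taken into a functional assay on MCF7 cells (Homo sapiens) for cytotoxicity, read by MTT assay, with a stated time of 72 h; on this read-out higher numbers stand for weaker inhibition and lower numbers for stronger inhibition. Compound 1 `N#Cc1ccc(/C=N/NC(=O)Nc2cc3c(Nc4ccc(F)c(Cl)c4)ncnc3cc2O[C@H]2CCOC2)cc1` has no number there, and its entry reads "not determined" (no result reported). Compound 2 `O=C(N/N=C/c1ccc(F)cc1Cl)Nc1cc2c(Nc3ccc(F)c(Cl)c3)ncnc2cc1O[C@H]1CCOC1` gives 32200 nM. Compound 3 `COc1ccc(/C=N/NC(=O)Nc2cc3c(Nc4ccc(F)c(Cl)c4)ncnc3cc2O[C@H]2CCOC2)cc1` gives 27300 nM. Going by the values given here, compound 3 therefore stands level with compound 2, the only other compound with a number, as their two values lie within the scatter of each other.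

The next compound, compound 4 `O=C(N/N=C/c1ccc(O)c(Br)c1)Nc1cc2c(Nc3ccc(F)c(Cl)c3)ncnc2cc1O[C@H]1CCOC1`, keeps the core and changes one group on a carbon with a double bond to nitrogen, with 3-bromo-4-hydroxyphenyl in place of 4-methoxyphenyl on a carbon with a double bond to nitrogen. Among the compounds with values here, only one measured step bears on this change: a 1.2-fold lower number from compound 2 to compound 3 (0.07 log units; within the scatter). In that step, 4-methoxyphenyl took the place of 2-chloro-4-fluorophenyl in the same location, and the difference stayed within the scatter. Within the data shown here, this is thin evidence, since it is a single step and no measured compound carries the 3-bromo-4-hydroxyphenyl group. On this basis, no shift beyond the scatter is expected in either direction, and the expected change is a 1.1-fold lower number from compound 3 to compound 4 (0.04 log units; within the scatter). For compound 4 the estimate is 25000 nM, with an expected range from 10000 nM to 55000 nM.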

Compound 4, half-maximal inhibitory concentration: 2690 nM
The estimate for compound 4 lay 9.3-fold (0.97 log units) above the measured number; measured number below the stated range.
By their numbers in this assay, from the lowest: compound 4; then compounds 3 and 2 (each within the scatter of the next).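

In this assay, the place on a carbon with a double bond to nitrogen proved sensitive to the group it carries: 3-bromo-4-hydroxyphenyl gives a large step from 4-methoxyphenyl (a 10-fold lower number from compound 3 to compound 4 (1.01 log units; beyond the scatter)) and a large step from 2-chloro-4-fluorophenyl (a 12-fold lower number from compound 2 to compound 4 (1.08 log units; beyond the scatter)), whereas the earlier exchange between those two groups had stayed within the scatter. The change keeps the count of heavy atoms and of hydrogen-bond acceptors, while the entering group brings a bromine and a hydrogen-bond donor, neither of which is present in 4-methoxyphenyl. No measurement shown here explains why this group gives the lower number.

The bromine and the hydroxyl arrive together in one group, so the compounds shown cannot separate their contributions, as none carries a phenyl group with only one of the two. They also leave open whether another halogen such as chlorine or iodine in place of the bromine, or an amine in place of the hydroxyl, would keep a step of this size.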